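Phenyl in place of vinyl: the step to compound 3

The source may report more compounds than this note shows. Statements on the series, on what has been measured and on what is new or still open speak of the compounds shown alone.

For the measured compounds named here, in a functional assay on CUTLL1 cells (Homo sapiens) for inhibition, read by resazurin assay, with a stated time of 48 h, in the presence of a further agent that is not named here (a lower number here means that less compound is needed, a higher number that more compound is needed for the effect), only two compounds have values so far. Compound 1 (`Nc1ncc(-c2ccncc2Br)c(C2CC2)n1`) gives 75000 nM, and compound 2 (`C=Cc1cnccc1-c1cnc(N)nc1C1CC1`) gives 29000 nM, the lower of the two numbers.

The next structure is compound 3 (`Nc1ncc(-c2ccncc2-c2ccccc2)c(C2CC2)n1`), with phenyl in place of vinyl on an aromatic carbon. Going by the values given here, the change falls on the same aromatic carbon that carried the one measured change, vinyl in place of bromo. That gives a single step to go on: a 2.6-fold lower number from compound 1 to compound 2 (0.41 log units; beyond the scatter). Among the compounds with values here, it is modest, and no measured compound yet shows how an aromatic ring behaves at this carbon, so the direction is tentative.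

On that thin basis, another modest move towards a lower number in this assay is expected, with no move beyond the scatter also plausible. The expected step is a 1.8-fold lower number from compound 2 to compound 3 (0.26 log units; within the scatter). For compound 3 the estimate is 16000 nM, with an expected range of 5000 nM to 50000 nM.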

Compound 3, half-maximal effective concentration: > 100000 nM
Compound 3: a limit, no number; the forecaster's own chance of this, stated with the estimate: 10%; at least 6.2-fold (0.79 log units) between middle value and limit.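

In this assay, for the compounds shown here, phenyl on this aromatic carbon reverses the direction of the one earlier step, giving an at least 3.4-fold higher number from compound 2 to compound 3 (0.53 log units; beyond the scatter), so the gain from bromo to vinyl does not carry over to phenyl. Phenyl in place of bromo gives an at least 1.3-fold higher number from compound 1 to compound 3 (0.12 log units; that floor lies within the scatter), so this pair supports only a floor, and the printed step does not separate the two compounds beyond the scatter. The value of compound 3 is a limit and not a number, so the full size of both steps remains unknown: the limit of > 100000 nM in this assay, at which 1 of the 3 values shown sits.

The three groups shown at this carbon do not separate the effect of group size from that of an aromatic ring, since phenyl differs from vinyl in both its heavy-atom count and its ring. An ethyl or a methoxy group would test whether a small group other than vinyl keeps the lower number of compound 2, and an amine or a carboxylic acid at the same carbon would extend the comparison to groups that carry hydrogen-bond donors or acceptors.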